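The compounds below may be only part of what the source reports. "The series", "measured", "known", "first", "only" and "open" are said of these compounds alone.

Measured so far in a functional assay on HCT-116 cells (Homo sapiens) for inhibition, read by sulforhodamine B assay, with a stated time of 48 h, tested at 50 uM; on this read-out higher numbers stand for more inhibition of growth at the one concentration tested and lower numbers for less inhibition of growth:
- Compound 1 `COc1ccc(/C=C/C(=O)/C=C/c2ccc(OCc3cn(CCCCOc4cc(=O)oc5ccccc45)nn3)c(OC)c2)cc1OC`: 55%
- Compound 2 `COc1cc(/C=C/C(=O)/C=C/c2cc(OC)c(OC)c(OC)c2)ccc1OCc1cn(CCOc2cc(=O)oc3ccccc23)nn1`: 89%

Of these two, compound 1 stands lower, and the gap up to compound 2 lies beyond the usual scatter. Compound 3 `COc1cc(/C=C/C(=O)/C=C/c2cc(OC)c(OC)c(OC)c2)ccc1OCc1cn(CCCCOc2cc(=O)oc3ccccc23)nn1` comes from compound 1 by one change: methoxy in place of hydrogen on an aromatic carbon, which turns 3,4-dimethoxyphenyl into 3,4,5-trimethoxyphenyl. For the measured compounds named here, no measured pair shows this change alone, so its size remains uncertain. The high number of compound 2 at 89% makes a rise in this assay beyond the scatter the likely outcome. The expected change is a number 19 percentage points higher from compound 1 to compound 3 (beyond the scatter). For compound 3 the estimate is 74%, with an expected range of 58% to 90%.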

Compound 3, percent growth inhibition at one concentration: 63%
Estimate against measurement, compound 3: 11 percentage points above; the measured number falls inside the stated range.
By their numbers in this assay, from the lowest: compounds 1 and 3 (each within the scatter of the next); then compound 2.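

In this assay, methoxy in place of hydrogen on the aromatic carbon gives a number a number 8 percentage points higher from compound 1 to compound 3 (within the scatter). For the compounds shown here, this is the first pair that shows the change from 3,4-dimethoxyphenyl to 3,4,5-trimethoxyphenyl alone, and the two compounds cannot be told apart on this read-out at the one concentration tested. No measurement at hand offers an explanation for this result.

Still open, going by these compounds, is whether an amine or a fluorine atom at this position would give a clearly different number. Also open, on these data alone, is whether the same methoxy change would give a similar step on a compound with a longer chain.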